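A Terpenyl Chain Added to Compound 1

The source may hold more compounds than are shown below. What is called first, only, known or untested is meant among the compounds shown, and "the series" means these compounds.

Among the measured compounds shown here, in a functional assay on HeLa cells (Homo sapiens) for cytotoxicity, read by XTT assay, with a stated time of 72 h (a lower number here means a stronger inhibitor, a higher number a weaker inhibitor), compound 1 `CC(C)=CCC/C=C(\C)Cc1c(O)cc(O)c2c(=O)cc(-c3ccccc3)oc12` gives 19000 nM, the only actual number available so far. Compound 2 `C=C1CC[C@H]2C(C)(C)CCC[C@]2(C)[C@H]1CC/C(C)=C/COc1cc(O)c2c(=O)c(OC/C=C(\C)CC[C@H]3C(=C)CC[C@H]4C(C)(C)CCC[C@]34C)c(-c3ccc(OC)cc3)oc2c1` reads > 100000 nM, and this is a limit, not a number.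

Compound 3 `CC(C)=CCC/C=C(\C)Cc1c(OC/C=C(\C)CCC=C(C)C)cc(O)c2c(=O)cc(-c3ccccc3)oc12` departs from compound 1 in one place: 3,7-dimethylocta-2,6-dien-1-yl in place of hydrogen on an oxygen on an aromatic ring. In words, 3,7-dimethylocta-2,6-dien-1-yl stands in place of hydrogen on an oxygen on an aromatic ring, so that hydroxy becomes (3,7-dimethylocta-2,6-dien-1-yl)oxy.

For the measured compounds named here, no measured pair shows this change on its own, which leaves the expectation loose. A moderate move towards weaker inhibition in this assay is expected, though it may not clear the usual scatter by much. The estimated change is a 2.1-fold higher number from compound 1 to compound 3 (0.32 log units; beyond the scatter). For compound 3 the expected value is 40000 nM, with an estimated range of 13000 nM to 100000 nM.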

Compound 3, half-maximal inhibitory concentration: > 100000 nM
Compound 3 ended at the assay's limit (the forecaster's own chance of this, stated with the estimate: 35%); at least 2.5-fold (0.39 log units) between middle value and limit.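

Among the compounds shown here, replacing the hydrogen on this oxygen on an aromatic ring with 3,7-dimethylocta-2,6-dien-1-yl gives the first comparison in this assay of compounds that differ in one place, and the change is an at least 5.2-fold higher number from compound 1 to compound 3 (0.72 log units; beyond the scatter). For compound 3 the entry of > 100000 nM is a limit of the assay, not a number. The step is therefore only a lower bound, and its full size cannot be read because the readings stop there: the limit of > 100000 nM in this assay, at which 2 of the 3 values shown sit.

The compounds shown leave open whether any group on this oxygen would have the same effect or whether it takes a chain of this size. A small methyl group or a chain ending in a carboxylic acid at this place would separate those two readings.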